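The compounds below may be only part of what the source reports. "The series", "measured", "known", "first", "only" and "open" are said of these compounds alone.

Compound 1, `Cc1nc(-c2ccc(C(F)(F)F)cc2)sc1CNc1ccc([C@H]2C[C@@H]2C(N)=O)cc1`, and compound 2, `Cc1nc(-c2ccc(C(F)(F)F)cc2)sc1CNc1ccc([C@H]2C[C@@H]2C(=O)N(C)C)cc1`, share one core and differ only at the carbonyl carbon attached to the saturated ring. In a functional assay on CHO cells for agonist activity at Free fatty acid receptor 1 (Homo sapiens), read by a luciferase reporter (a lower number here means a smaller maximal response, a higher number a larger maximal response), compound 1 gives 80%, while compound 2 gives 49%. For the measured compounds named here, the single step that links them, a number 31 percentage points lower from compound 1 to compound 2 (beyond the scatter), sets compound 2 at the lowest of the two numbers measured so far, with compound 1 as its only neighbour.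

Compound 3, `Cc1nc(-c2ccc(C(F)(F)F)cc2)sc1CNc1ccc([C@H]2C[C@@H]2C(=O)N[C@H](C)c2ccccc2)cc1`, is not yet measured. It departs from compound 2 by a change at the same carbonyl carbon: (1-phenylethyl)amino in place of dimethylamino on a carbonyl carbon. The step from compound 1 to compound 2 is the only measured one that bears on this position, and it was large. Compound 3 neither returns to the amino group of compound 1 nor keeps the dimethylamino group of compound 2, so that step gives direction only loosely. The maximal response of compound 3 is expected to land between the two measured values, a moderate rise a number 11 percentage points higher from compound 2 to compound 3 (beyond the scatter) over compound 2. The estimate for compound 3 is therefore 60%, within a range from 35% to 85%.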

Compound 3, largest response reached (reported as percent of maximum), in percent of the reference or control that the assay uses: 42%
Estimate against measurement, compound 3: 18 percentage points above, within the range that was stated.
By their numbers in this assay, from the lowest: compounds 3 and 2 (each within the scatter of the next); then compound 1.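

At the carbonyl carbon, the change from dimethylamino to (1-phenylethyl)amino brings in a six-membered aromatic ring, a hydrogen-bond donor and a defined stereocentre, yet in this assay it gives a number 7 percentage points lower from compound 2 to compound 3 (within the scatter) and so does not separate the two groups by maximal response. Placing 1-phenylethyl on the amide-type nitrogen of compound 1 gives a number 38 percentage points lower from compound 1 to compound 3 (beyond the scatter) and, read with a number 31 percentage points lower from compound 1 to compound 2 (beyond the scatter) as the earlier step, shows that the large difference is not confined to dimethylamino: among these three compounds, the two with substituted nitrogen both lie beyond the scatter from the compound with the plain amino group. No measurement at hand accounts for this result.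

The compounds shown leave open whether a single small group on the nitrogen, as in methylamino, already separates from the amino group of compound 1, or whether that response is kept only with both amide hydrogens in place. They also leave open how benzylamino, the opposite stereoisomer of the 1-phenylethyl group, or a carboxylic acid at the same carbonyl carbon would compare.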